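A few compounds are considered here, and "the series" means these few. Any claim that something is new, unique, unknown or untested is made for them only; others in the source may bear on it.

Compound 3 `Oc1ccc(/C=C/C[C@H]2C[C@@H]([C@@H](O)c3ccccc3)CO[C@@H]2c2ccccc2)cc1` gives 7380 nM in a functional assay on HL-60 cells (Homo sapiens) for cytotoxicity, read by WST assay, with a stated time of 48 h (a higher number here means a weaker inhibitor, a lower number a stronger inhibitor), the low end of the two numbers shown, though compound 2 `COc1cccc(/C=C/C[C@H]2C[C@@H]([C@@H](O)c3ccccc3)CO[C@@H]2c2ccccc2)c1` gives 9620 nM and the step of a 1.3-fold lower number from compound 2 to compound 3 (0.12 log units; within the scatter). Compound 1 `O[C@@H](c1ccccc1)[C@H]1CO[C@H](c2ccccc2)[C@@H](C/C=C/c2ccncc2)C1` gives only a limit in this assay, > 100000 nM (the limit of > 100000 nM in this assay, at which 1 of the 3 values shown sits). Compound 4 `O[C@@H](c1ccccc1)[C@H]1CO[C@H](c2ccccc2)[C@@H](C/C=C/c2cccnc2)C1` differs from compound 3 in one place: pyridin-3-yl in place of 4-hydroxyphenyl on a double-bonded chain carbon bound to a double-bonded chain carbon. The measured steps that bear on this run the other way: an at least 13-fold lower number from compound 1 to compound 3 (1.13 log units; beyond the scatter), and similarly an at least 10-fold lower number from compound 1 to compound 2 (1.01 log units; beyond the scatter). A pyridinyl group at this place thus returned only a limit, although it was pyridin-4-yl rather than pyridin-3-yl. For compound 4 a large upward step is therefore expected, an 8.1-fold higher number from compound 3 to compound 4 (0.91 log units; beyond the scatter). Compound 4 is estimated in this assay at 60000 nM, between 15000 nM and 200000 nM.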

Compound 4, half-maximal inhibitory concentration: > 100000 nM
Compound 4 ended at the assay's limit; the forecaster's own chance of this, stated with the estimate: 40%; at least 1.6-fold (0.22 log units) between middle value and limit.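

The result gives an at least 13-fold higher number from compound 3 to compound 4 (1.13 log units; beyond the scatter) and an at least 10-fold higher number from compound 2 to compound 4 (1.01 log units; beyond the scatter) in this assay, so the large upward step at this place is no longer tied to pyridin-4-yl alone: pyridin-3-yl gives it too. Compound 1 and compound 4 both stand at a limit, not at a number: the limit of > 100000 nM in this assay, at which 2 of the 4 values shown sit. The step between these two cannot be read, so the two pyridinyl groups cannot be ranked. From the compounds shown here alone, it remains open whether a plain phenyl or a 4-aminophenyl group on this chain carbon would stay at this limit or give a number like those of compound 2 and compound 3.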